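The source may hold more compounds than are shown below. What is called first, only, known or untested is meant among the compounds shown, and "the series" means these compounds.

Compound 1, `COc1ccc(-n2nc(Sc3ccc(Cl)cc3)cc(CC[C@@H](C)NC(=O)[C@H]3CNCC[C@@H]3c3ccc(Cl)cc3)c2=O)cc1`, in a functional assay with Melanocortin receptor 4 (Homo sapiens) as the target, read by cAMP accumulation (on this read-out lower numbers stand for an effect already at smaller amounts and higher numbers for an effect only at larger amounts of compound), compound 1 gives 210 nM. Compound 2, `COc1ccc(-n2nc(Sc3ccc(Cl)cc3)cc(CC[C@@H](C)NC(=O)[C@H]3CNCC[C@@H]3c3ccccc3F)c2=O)cc1`, gives 550 nM. Compound 3, `COc1ccc(-n2nc(Sc3ccc(Cl)cc3)cc(CC[C@@H](C)NC(=O)[C@H]3CNCC[C@@H]3c3ccc(C(F)(F)F)cc3)c2=O)cc1`, gives only a limit of this assay, > 5000 nM.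

Compound 3 thus stands at the weak end of the three: its value is not a number but the limit (the limit of > 5000 nM in this assay, at which 1 of the 3 values shown sits). Compound 4, `COc1ccc(-n2nc(Sc3ccc(Cl)cc3)cc(CC[C@@H](C)NC(=O)[C@H]3CNCC[C@@H]3c3ccc(C)cc3)c2=O)cc1`, differs from compound 3 in one place: methyl in place of trifluoromethyl on an aromatic carbon, para to a large group. Among the compounds with values here, two measured steps bear on this. From compound 1 to compound 3, trifluoromethyl in place of chloro cost an at least 23-fold higher number from compound 1 to compound 3 (1.37 log units; beyond the scatter). From compound 2 to compound 3 the cost was an at least 9.0-fold higher number from compound 2 to compound 3 (0.95 log units; beyond the scatter), while a 2.6-fold higher number from compound 1 to compound 2 (0.42 log units; beyond the scatter) shows a smaller shift. Since the trifluoromethyl that leaves is the very group that accompanied the large loss, compound 4 is expected to recover much of it, with an expected step of an at least 11-fold lower number from compound 3 to compound 4 (1.04 log units; beyond the scatter). The estimate for compound 4 is 450 nM, within 150 nM to 1500 nM.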

Compound 4, half-maximal effective concentration: 1100 nM
Beside the measured number, compound 4's estimate is 2.4-fold (0.39 log units) below it, within the range that was stated.
By their numbers in this assay, from the lowest: compound 1; then compounds 2 and 4 (each within the scatter of the next). At a limit, above all of these: compound 3.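

Swapping trifluoromethyl for methyl on this aromatic carbon brings the compound back to a measurable number, with an at least 4.5-fold lower number from compound 3 to compound 4 (0.65 log units; beyond the scatter), so the loss seen with trifluoromethyl is not shared by every group at this place. The recovery is only partial, since methyl does not match chloro on the same carbon: the change gives a 5.2-fold higher number from compound 1 to compound 4 (0.72 log units; beyond the scatter). The 4-methylphenyl group also cannot be told apart from the 2-fluorophenyl group on the saturated ring carbon, as the comparison gives a 2.0-fold higher number from compound 2 to compound 4 (0.30 log units; within the scatter).

The true size of the gain from trifluoromethyl to methyl stays open because compound 3 has a limit and not a number: the limit of > 5000 nM in this assay, at which 1 of the 4 values shown sits. The compounds shown also leave open whether bromo, ethyl or a nitrile on this aromatic carbon would come closer to chloro than methyl does.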